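The compounds below may be only part of what the source reports. "The series", "measured", "known", "first", "only" and "open" are said of these compounds alone.

Compound 1 `C=C1CCCC(C)(C)[C@@H]1C[C@@H](O)/C(C)=C/CC[C@@H]1[C@@]2(C)CCCC(C)(C)[C@@H]2CC[C@@]1(C)O`: > 10 ug/mL (a limit)
Compound 2 `C=C1CCCC(C)(C)[C@@H]1CC(=O)/C(C)=C/CC[C@@H]1[C@@]2(C)CCCC(C)(C)[C@@H]2CC[C@@]1(C)O`: 6.8 ug/mL

In an ADME assay on Hepa 59T/VGH cells (Homo sapiens) for cytotoxicity, read by MTT assay (on this read-out higher numbers stand for an effect only at larger amounts of compound and lower numbers for an effect already at smaller amounts), compound 1 gives > 10 ug/mL, which is a limit and not a number. Its true position is therefore unknown. Compound 2, by contrast, gives a measured number, 6.8 ug/mL.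

Compound 3 `C=C1CCCC(C)(C)[C@@H]1C[C@@H](OC(=O)c1ccccc1)/C(C)=C/CC[C@@H]1[C@@]2(C)CCCC(C)(C)[C@@H]2CC[C@@]1(C)O` keeps the core of compound 1 but has benzoyl in place of hydrogen on an oxygen on a saturated carbon. Within the data shown here, no measured pair shows what this change does. Only a small move towards lower numbers is expected, an at least 1.1-fold lower number from compound 1 to compound 3 (0.04 log units; that floor lies within the scatter). The estimated value for compound 3 is 9 ug/mL, with an expected range of 4 ug/mL to 20 ug/mL.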

Compound 3, concentration for half-maximal effect: > 10 ug/mL
Compound 3: a limit, no number; the forecaster's own chance of this, stated with the estimate: 45%; at least 1.1-fold (0.04 log units) between middle value and limit.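

In this assay compound 3 gives > 10 ug/mL as a limit and not a number. Compound 1 also stands at a limit, so no step can be read between compound 1 and compound 3: the limit of > 10 ug/mL in this assay, at which 2 of the 3 values shown sit. Still open, going by these compounds, is how far benzoyl in place of hydrogen on an oxygen on a saturated carbon moves the value, if at all.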